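A few compounds are considered here, and "the series" means these few. Any claim that something is new, unique, unknown or untested is made for them only; others in the source may bear on it.

Two chromone carboxylic acids share an identical set of atoms arranged in two different ways. Compound 1 `O=C(O)c1cc(=O)c2cc(OCCCOc3ccccc3)ccc2o1` and compound 2 `O=C(O)c1cc(=O)c2cc(OCCCCCOc3ccccc3)ccc2o1` carry an ether chain on one position of the shared core; compound 3 `O=C(O)c1cc(=O)c2cccc(OCCCOc3ccccc3)c2o1` carries the same kind of chain on another position, and the difference between the two cores is not broken down here. Compound 4 `O=C(O)c1cc(=O)c2cccc(OCCCCCOc3ccccc3)c2o1` belongs to the core of compound 3.

In a functional assay on ileum (Cavia porcellus) for antagonist activity, with a stated time of 30 s (on this read-out lower numbers stand for stronger inhibition and higher numbers for weaker inhibition), compound 1 gives 3.3 ug/mL, and compound 2 gives 3.3 ug/mL. The change from compound 1 to compound 2 is 2-phenoxyethyl in place of phenoxy on a saturated chain carbon, three bonds along the chain from an oxygen on an aromatic ring, and the measured step is no change at the digits printed from compound 1 to compound 2 (within the scatter). Compound 3 in this assay gives 50 ug/mL, the highest number of the three measured compounds and beyond the scatter from both compound 1 and compound 2.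

The change from compound 3 to compound 4 is 2-phenoxyethyl in place of phenoxy on a saturated chain carbon, three bonds along the chain from an oxygen on an aromatic ring, the same change as that from compound 1 to compound 2, made on the other core. Among the measured compounds shown here, since the only precedent for this change, the step from compound 1 to compound 2, left the number unchanged within the scatter, the step from compound 3 to compound 4 is expected to be about no change at the digits printed from compound 3 to compound 4 (within the scatter). On that basis compound 4 is estimated to give about 50 ug/mL in this assay, most likely between 20 ug/mL and 120 ug/mL, because compound 3 gives 50 ug/mL and the chain lengthening itself did nothing measurable in the one case where it was tested.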

Compound 4, half-maximal inhibitory concentration: 9 ug/mL
For compound 4 the middle estimate is 5.6-fold (0.74 log units) above the measured one, and the stated range ends above it.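

Set side by side in this assay, the same change does not behave alike on the two cores: the same change on two cores in this assay, no change at the digits printed (within the scatter) from compound 1 to compound 2 and a 5.6-fold lower number (0.74 log units; beyond the scatter) from compound 3 to compound 4, 5.6-fold (0.74 log units) apart, beyond the scatter of two such steps

On the core of compound 3, putting 2-phenoxyethyl in place of phenoxy gives a 5.6-fold lower number from compound 3 to compound 4 (0.74 log units; beyond the scatter), and since a lower number stands for stronger inhibition, the change improves inhibition on this core, so a step measured on one core in this series cannot simply be assumed to hold on the other. Among the compounds shown here, this does not show why the two cores respond differently, and with only one pair of compounds on each core it gives no general rule about how either core responds to other changes, nor does it show whether the same difference would appear in any other assay.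

From the compounds shown here alone, it remains open whether a still longer chain would extend the gain seen on the core of compound 3 or reverse it, and whether such a chain would leave the number for the core of compound 1 as flat as this change did. Also open, going by these compounds, is how either core would respond to an amine in the chain or to an amide in place of the carboxylic acid.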